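A few compounds are considered here, and "the series" means these few. Any claim that something is new, unique, unknown or untested is made for them only; others in the source may bear on it.

Measured so far in an assay for inhibition of 3-hydroxy-3-methylglutaryl-coenzyme A reductase (Rattus norvegicus); on this read-out higher numbers stand for weaker inhibition and lower numbers for stronger inhibition:
Compound 1 `O=C1C[C@H](O)C[C@@H](/C=C/c2c(Cl)cc(Cl)cc2-c2cc(Cl)cc(Cl)c2)O1` gives 37 nM
Compound 2 `Cc1cc(-c2cc(Cl)cc(C)c2/C=C/[C@@H]2C[C@@H](O)CC(=O)O2)ccc1F` gives 6 nM
Compound 3 `Cc1cccc(-c2cc(Cl)cc(Cl)c2/C=C/[C@@H]2C[C@@H](O)CC(=O)O2)c1` gives 16 nM

Compound 3 holds the second highest number of the three: compound 1 sits a step above it and compound 2 a step below it. Compound 4 `COc1ccc(-c2cc(Cl)cc(Cl)c2/C=C/[C@@H]2C[C@@H](O)CC(=O)O2)cc1` differs from compound 3 in one place: 4-methoxyphenyl in place of 3-methylphenyl on an aromatic carbon. For the measured compounds named here, only one measured step concerns an exchange of this aryl group on the shared core: a 2.3-fold lower number from compound 1 to compound 3 (0.36 log units; beyond the scatter), a modest move. Compound 2 carries a different core, so its lower number cannot be tied to the aryl group alone. Since swapping one aryl group for another has so far shifted this assay only modestly, compound 4 is expected to land close to compound 3, with the estimated step of a 1.1-fold lower number from compound 3 to compound 4 (0.03 log units; within the scatter) staying within the scatter. Compound 4 is estimated at 15 nM, in the range 6 nM to 40 nM.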

Compound 4, half-maximal inhibitory concentration: 470 nM
The estimate for compound 4 lay 31-fold (1.50 log units) below the measured number; the whole stated range lies below it.
By their numbers in this assay, from the lowest: compound 2; then compound 3; then compound 1; then compound 4.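

In this assay, for the compounds shown here, this position proves far less forgiving than the earlier compounds suggested: 4-methoxyphenyl in place of 3-methylphenyl gives a 29-fold higher number from compound 3 to compound 4 (1.47 log units; beyond the scatter), and 4-methoxyphenyl in place of 3,5-dichlorophenyl gives a 13-fold higher number from compound 1 to compound 4 (1.10 log units; beyond the scatter). Changing the aryl group on this aromatic carbon can therefore weaken inhibition sharply, not just shift it modestly. No available measurement explains this drop. Still open, on these data alone, is whether it follows from the methoxy group itself or from where that group sits, a question that 3-methoxyphenyl and 4-methylphenyl groups at this position could help separate.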